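From 2-hydroxyethyl to ethoxy: expecting compound 4

A few compounds are considered here, and "the series" means these few. Any claim that something is new, unique, unknown or untested is made for them only; others in the source may bear on it.

Compound 1 `COCc1nc2nc(C)cc(Nc3ccc(C(F)(F)F)cc3)n2n1`: 150000 nM
Compound 2 `Cc1cc(Nc2ccc(C(F)(F)F)cc2)n2nc(CCO)nc2n1`: 19000 nM
Compound 3 `Cc1cc(Nc2ccc(S(F)(F)(F)(F)F)cc2)n2nc(C3CC3)nc2n1`: 16000 nM

In a physicochemical assay for solubility, at pH 6.5 (on this read-out higher numbers stand for higher solubility and lower numbers for lower solubility), compound 2 gives 19000 nM, within the scatter of compound 3 at 16000 nM, while compound 1 stands clearly higher at 150000 nM. Compound 4 `CCOc1nc2nc(C)cc(Nc3ccc(C(F)(F)F)cc3)n2n1` differs from compound 2 by ethoxy in place of 2-hydroxyethyl on an aromatic carbon. Among the compounds with values here, one measured step bears on this change: a 7.9-fold lower number from compound 1 to compound 2 (0.90 log units; beyond the scatter), with hydroxymethyl in place of methoxy on a saturated chain carbon bound to an aromatic carbon. The new change runs the opposite way, with a hydroxyl-bearing chain leaving, but it is not the same exchange, so only part of that size is expected to return, as a higher number. The expected change is a 3.2-fold higher number from compound 2 to compound 4 (0.50 log units; beyond the scatter). Compound 4 is estimated at 60000 nM, with an expected range of 20000 nM to 160000 nM.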

Compound 4, solubility: 19000 nM
The estimate for compound 4 lay 3.2-fold (0.50 log units) above the measured number; measured number outside the range, below it.
By their numbers in this assay, from the lowest: compounds 3, 2 and 4 (each within the scatter of the next); then compound 1.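

In this assay, ethoxy in place of 2-hydroxyethyl on the aromatic carbon between two ring nitrogen atoms gives no change at the digits printed from compound 2 to compound 4 (within the scatter), so removing the hydroxyl-bearing chain does not by itself recover the number of compound 1. Ethoxy in place of methoxymethyl gives a 7.9-fold lower number from compound 1 to compound 4 (0.90 log units; beyond the scatter), which shows that two chains without a hydroxyl can differ clearly at this position. Nothing measured here explains that difference. As far as these compounds go, whether a longer ether chain or an amine at this position would stand with compound 1 or with compound 4 remains open.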